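Swapping the aryl group on sulfur: compound 3 assessed

The source may report more compounds than this note shows. Statements on the series, on what has been measured and on what is new or still open speak of the compounds shown alone.

Compound 1 `Nc1ccccc1NC(=O)/C=C/c1ccc(CSc2cccc(F)c2)cc1` and compound 2 `Nc1ccccc1NC(=O)/C=C/c1ccc(CSc2cccc3ccccc23)cc1` share a common core and differ only in the group on the sulfur. In a functional assay on HCT-116 cells (Homo sapiens) for inhibition, read by CCK-8 assay, with a stated time of 72 h, tested at 2 uM (a higher number here means more inhibition of growth at the concentration tested, a lower number less inhibition of growth), compound 1 gives 7.95% and compound 2 gives 11%. Going by the values given here, the single step between them, a number 3.1 percentage points higher from compound 1 to compound 2 (within the scatter), is within the scatter, so compound 2 stands at the top of the two numbers only nominally and is not separated from compound 1. Compound 3 `CCc1ccc(SCc2ccc(/C=C/C(=O)Nc3ccccc3N)cc2)cc1` is the next variation at the same sulfur: 4-ethylphenyl in place of naphthalen-1-yl on a sulfur. Among the compounds with values here, the one measured step at this position was small, within the scatter, and it is the only evidence bearing on this change, so compound 3 is expected to show no step beyond the scatter in this assay, with a number 2 percentage points lower from compound 2 to compound 3 (within the scatter) as the expected shift. Compound 3 is therefore estimated at 9%, in a range from 0% to 20%.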

Compound 3, percent growth inhibition at one concentration: 3.29%
Compound 3: middle estimate off by 5.7 percentage points, on the high side; the measured number falls inside the stated range.
By their numbers in this assay, from the lowest: compounds 3, 1 and 2 (each within the scatter of the next).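

In this assay, a third aryl group on the sulfur still does not separate the compounds: there is a number 7.7 percentage points lower from compound 2 to compound 3 (within the scatter), and a number 4.7 percentage points lower from compound 1 to compound 3 (within the scatter). With 4-ethylphenyl, one six-membered aromatic ring in place of the two of naphthalen-1-yl makes no difference beyond the scatter, so naphthalen-1-yl, 3-fluorophenyl and 4-ethylphenyl cannot be told apart in this read-out. No other data bear on this result.

All three groups are aryl groups, so the compounds shown leave open whether a non-aryl group on the sulfur, such as an amine, a carboxylic acid or a longer chain, would give a step beyond the scatter. They also leave open whether any of these compounds would be separated at a concentration other than the one tested.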